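The compounds below may be only part of what the source reports. "The series", "measured", "known", "first", "only" and "open" are said of these compounds alone.

Compound 1 `C=CC1=C(C(=O)O)C(c2ccc(OC)cc2)OC1` — in a functional assay on A549 cells (Homo sapiens) for cytotoxicity, read by MTT assay, with a stated time of 24 h (a lower number here means a stronger inhibitor, a higher number a weaker inhibitor), compound 1 gives > 100000 nM, a limit of the assay.
Compound 2 `C=CC1=C(C(=O)NC(C)(C)C)C(c2ccc(OC)cc2)OC1` — in this assay compound 2 gives > 100000 nM, also a limit of the assay.

Compound 2 stands at the limit, not at a number, and the limit of > 100000 nM in this assay, at which 2 of the 2 values shown sit, marks where both values of the series sit. For the measured compounds named here, the one measured step, a step that the two limits leave unreadable from compound 1 to compound 2, is unreadable: both of its ends are limits, so the size of the change on going from a hydroxy to a (tert-butyl)amino on the carbonyl carbon is not known.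

Compound 3 `C=CC1=C(C(=O)NCc2ccc(Cl)cc2)C(c2ccc(OC)cc2)OC1` differs from compound 2 by 4-chlorobenzyl in place of tert-butyl on an amide-type nitrogen. Going by the values given here, no measured step bears on this change; the only step in hand is itself unreadable, so nothing points to a step in either direction beyond the scatter in this assay. The step of a number no higher from compound 2 to compound 3 (the limit leaves the size open) is therefore expected to be small or unreadable. Compound 3 is estimated at 100000 nM, with a range from 30000 nM to 300000 nM, and most likely reported only as a limit.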

Compound 3, half-maximal inhibitory concentration: > 100000 nM
Compound 3: only a limit was reported (the forecaster's own chance of this, stated with the estimate: 75%); the middle value sits exactly at the limit.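

No step can be read between compound 2 and compound 3, as each stands only at a limit of the assay: the limit of > 100000 nM in this assay, at which 3 of the 3 values shown sit.

Going by these compounds, what stays open is where compound 1, compound 2 or compound 3 would fall as a number, and so the size of either change on the carbonyl side.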